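The source may report more compounds than this note shows. Statements on the series, on what has been measured and on what is new or still open speak of the compounds shown alone.

Measured compounds:
compound 1, `C=CCn1c(=O)/c(=C\c2ccccc2F)[nH]c(=O)/c1=C\c1ccccc1OC`, in a functional assay on K562 cells (Homo sapiens) for cytotoxicity, read by CCK-8 assay, with a stated time of 72 h (on this read-out lower numbers stand for stronger inhibition and higher numbers for weaker inhibition), gives 5600 nM;
compound 2, `C=CCn1c(=O)/c(=C\c2ccc(C)cc2)[nH]c(=O)/c1=C\c1ccccc1OC`, in this assay gives "not active" (no number reported).

Compound 2 stands without a number on this read-out: in this assay it is reported only as inactive, so no figure places it against compound 1, which does carry a value. Compound 3, `C=CCn1c(=O)/c(=C\c2cccc(Cl)c2Cl)[nH]c(=O)/c1=C\c1ccccc1OC`, has not yet been measured. It differs from compound 2 in one place: 2,3-dichlorophenyl in place of 4-methylphenyl on a double-bonded chain carbon bound to an aromatic carbon.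

For the measured compounds named here, no step between measured compounds is available, so the size of the change from compound 2 to compound 3 cannot be read from the data. Compound 1 shows that a halogen-bearing phenyl at this position can give a measurable, if weak, value in this assay, whereas compound 2 with its 4-methylphenyl gives none. Compound 3 is therefore expected to fall in the weak range, estimated at 8000 nM, with a range from 2000 nM to 40000 nM, and a real chance that it too is reported only as inactive.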

Compound 3, half-maximal inhibitory concentration: 900 nM
Beside the measured number, compound 3's estimate is 8.9-fold (0.95 log units) above it; the measured number lies below the stated range.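

In this assay, 2,3-dichlorophenyl in place of 2-fluorophenyl on a double-bonded chain carbon bound to an aromatic carbon gives a 6.2-fold lower number from compound 1 to compound 3 (0.79 log units; beyond the scatter), so a change of aryl group at this place alone moves the number beyond the scatter. Compound 3, at 900 nM, also shows that a 4-methylphenyl reported as inactive in compound 2 can be replaced here by a group that gives a clear value. The step from compound 2 to compound 3 cannot be read, as compound 2 carries no number. Nothing shown here accounts for the difference between these aryl groups.

As far as these compounds go, whether the lower number rests on one chlorine or on both remains open. So does how a phenyl bearing an amine or a carboxylic acid would read at this place.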